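The source may report more compounds than this note shows. Statements on the series, on what has been measured and on what is new or still open speak of the compounds shown alone.

Working notes on the series.

Compound 1, `CC(C(=O)N1CCN(c2ccccc2)CC1)N1C(=O)CCC1=O`, sits second highest of the three numbers in hand: in a functional assay on the whole organism (strain Swiss) with Mus musculus as the target, in the maximal electroshock model, with a stated time of 1 h, at a dose of 300 mg/kg by the intraperitoneal route (a higher number here means a stronger effect of the compound at the dose given, a lower number a weaker effect), compound 1 gives 50%. Its nearest neighbour is compound 3, `CC(C(=O)N1CCN(c2ccccc2C(F)(F)F)CC1)N1C(=O)CCC1=O`, which in this assay gives 75%; furthest is compound 2, `CC(C(=O)N1CCN(c2ccc(C(F)(F)F)cc2)CC1)N1C(=O)CCC1=O`, which in this assay gives 0%.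

Compound 4, `CC(C(=O)N1CCN(c2cccc(C(F)(F)F)c2)CC1)N1C(=O)CCC1=O`, is not yet measured. It differs from compound 1 by trifluoromethyl in place of hydrogen on an aromatic carbon.

Among the compounds with values here, two measured steps bear on this change, both bringing the same group onto the aromatic ring of compound 1 at another place. One is a number 50 percentage points lower from compound 1 to compound 2 (beyond the scatter); the other is a number 25 percentage points higher from compound 1 to compound 3 (beyond the scatter). The same entering group thus moved the number in opposite directions, one loss large and one gain modest, so the direction for compound 4 is open and a step of either sign beyond the scatter is plausible, with no basis to favour the large loss over the modest gain.

Taking the middle ground between those two outcomes, compound 4 is expected to give about 40% in this assay, within a range from 0% to 75%, which is an expected step of a number 10 percentage points lower from compound 1 to compound 4 (within the scatter).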

Compound 4, a percentage reported as activity, at one dose (the size of the read-out at that dose, not a potency): 100%
The estimate for compound 4 lay 60 percentage points below the measured number; the measured number lies above the stated range.
By their numbers in this assay, from the lowest: compound 2; then compound 1; then compound 3; then compound 4.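

In this assay, trifluoromethyl on the aromatic carbon meta to a large group gives a number 50 percentage points higher from compound 1 to compound 4 (beyond the scatter), a gain that is large rather than modest and that matches in size the loss in a number 50 percentage points lower from compound 1 to compound 2 (beyond the scatter). The entering group is the same in compound 2, compound 3 and compound 4, so among these three steps from compound 1, the place on the ring alone sets the direction and size of the change, and this place now joins the one in compound 3 on the side of a gain. Nothing on hand accounts for this dependence on place.

Going by these compounds, whether a chlorine atom, a methoxy group or an amine at this same place would also raise the number remains open. On these data alone, the read-out comes from a single dose, so how compound 4 would behave at lower doses also remains open.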